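A few compounds are considered here, and "the series" means these few. Any claim that something is new, unique, unknown or untested is made for them only; others in the source may bear on it.

Of the compounds shown here, three sharing one core have been measured in an assay on CHO cells for displacement of a labelled ligand from Alpha-1A adrenergic receptor (Homo sapiens); on this read-out lower numbers stand for stronger inhibition and higher numbers for weaker inhibition. Compound 1 `COc1cccc(OC)c1OCCNCCOc1ccccc1OCc1ccccc1` gives 0.468 nM; compound 2 `COc1cccc(OC)c1OCCNCCOc1ccccc1OCc1cccc(Cl)c1` gives 0.251 nM; compound 3 `COc1cccc(OC)c1OCCNCCOc1ccccc1OCc1ccc(C)cc1` gives 2 nM. Compound 3 thus has the highest of the three numbers, with compound 1 nearest and compound 2 furthest. The measured steps are a 1.9-fold lower number from compound 1 to compound 2 (0.27 log units; within the scatter), a 4.3-fold higher number from compound 1 to compound 3 (0.63 log units; beyond the scatter) and an 8.0-fold higher number from compound 2 to compound 3 (0.90 log units; beyond the scatter). Compound 4 `COc1ccccc1COc1ccccc1OCCNCCOc1c(OC)cccc1OC`, not yet measured, differs from compound 3 by 2-methoxyphenyl in place of 4-methylphenyl on a saturated chain carbon bound to an oxygen on an aromatic ring. Among the measured compounds shown here, no measured step involves a methoxy group at this place, so the step from compound 1 to compound 3 is the closest guide: the methyl gave a higher number, and its removal is expected to bring the number back toward that of compound 1, while what the entering methoxy adds remains unknown and widens the range. The expected step is a 2.9-fold lower number from compound 3 to compound 4 (0.46 log units; beyond the scatter). In this assay compound 4 is therefore estimated to give 0.7 nM, with a range from 0.2 nM to 2.5 nM.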

Compound 4, inhibition constant: 2 nM
Estimate against measurement, compound 4: 2.9-fold (0.46 log units) below; the range from low to high includes it.
By their numbers in this assay, from the lowest: compounds 2 and 1 (each within the scatter of the next); then compounds 3 and 4 (each within the scatter of the next).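

In this assay, 2-methoxyphenyl in place of 4-methylphenyl on a saturated chain carbon bound to an oxygen on an aromatic ring gives no change at the digits printed from compound 3 to compound 4 (within the scatter) and so leaves the read-out where the methyl compound stood. The added methoxy gives a 4.3-fold higher number from compound 1 to compound 4 (0.63 log units; beyond the scatter) and 2-methoxyphenyl in place of 3-chlorophenyl gives an 8.0-fold higher number from compound 2 to compound 4 (0.90 log units; beyond the scatter) so that methoxy, like the methyl of compound 3, goes with a higher number than hydrogen, while the chloro of compound 2 goes against this pattern. No independent evidence bears on this result.

The compounds shown never place methyl and methoxy at the same ring carbon, so the group and its place on the ring cannot be told apart. As far as these compounds go, how a hydroxy, an amino or a trifluoromethyl group would read here also stays open.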